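Swapping Fluoro for Chloro at the Carbonyl-Side Ring

The compounds below may be only part of what the source reports. "The series", "measured", "known", "first", "only" and "open" are said of these compounds alone.

Of the compounds shown here, three sharing one core have been tested in an assay on MDA-MB-231 cells for binding affinity to C-X-C chemokine receptor type 4 (Homo sapiens), read by immunofluorescence and microscopy, with stated times of 10 min and 30 min; a higher number here means that more compound is needed for the effect, a lower number that less compound is needed. Compound 1 `O=C(NCc1ccc(CNS(=O)(=O)c2ccccc2)cc1)c1ccc(F)cc1` gives 100 nM. Compound 2 `Cc1ccc(S(=O)(=O)NCc2ccc(CNC(=O)c3ccccc3Cl)cc2)cc1` gives 10 nM. For the measured compounds named here, compound 3 `O=C(NCc1ccc(CNS(=O)(=O)c2ccccc2)cc1)c1ccccc1F` gives 1000 nM, the highest number of the three, and the one single-place step known, a 10-fold higher number from compound 1 to compound 3 (1.00 log units; beyond the scatter), moved it there. Compound 4 `O=C(NCc1ccc(CNS(=O)(=O)c2ccccc2)cc1)c1ccccc1Cl` differs from compound 3 in one place: chloro in place of fluoro on an aromatic carbon. Going by the values given here, no measured step covers this change directly. Compound 2 carries the same chloro-bearing ring on the carbonyl but also differs elsewhere, so its value can only hint that chloro here is tolerated. The expected step is therefore a 4.0-fold lower number from compound 3 to compound 4 (0.60 log units; beyond the scatter), toward a lower number. Compound 4 is estimated at 250 nM, within 30 nM to 2000 nM.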

Compound 4, effective concentration (reported as EC, without a stated level of effect): 10 nM
The estimate for compound 4 lay 25-fold (1.40 log units) above the measured number, and the stated range ends above it.
By their numbers in this assay, from the lowest: compounds 2 and 4 (each within the scatter of the next); then compound 1; then compound 3.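

In this assay, the identity of the halogen on this aromatic carbon, ortho to a large group, matters greatly: chloro in place of fluoro gives a 100-fold lower number from compound 3 to compound 4 (2.00 log units; beyond the scatter). The 2-chlorophenyl group in place of 4-fluorophenyl gives a 10-fold lower number from compound 1 to compound 4 (1.00 log units; beyond the scatter), while hydrogen in place of methyl on an aromatic carbon gives no change at the digits printed from compound 2 to compound 4 (within the scatter). No available evidence explains the large halogen step.

From the compounds shown here alone, whether bromo or methoxy on this same carbon would give a number closer to that of chloro or fluoro remains open.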